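This account rests on a few compounds, and the source may have more. Where it says the series, first, only, none or still open, it means among the compounds named here.

Measured so far in a physicochemical assay for metabolic stability, read by HPLC, tested at 2 mM; on this read-out lower numbers stand for a shorter-lived compound and higher numbers for a longer-lived compound:

Compound 1, `O=C(O[C@H]1C[C@H](n2cc(F)c(=O)[nH]c2=O)O[C@@H]1COP(=O)(O)Oc1cccnc1)c1ccccc1`, gives 6.7 h.
Compound 2, `O=C(O[C@H]1C[C@H](n2cc(F)c(=O)[nH]c2=O)O[C@@H]1COP(=O)(O)Oc1ccc2ncccc2c1)c1ccccc1`, gives 7.7 h.
Compound 3, `O=c1[nH]c(=O)n([C@H]2C[C@H](O)[C@@H](COP(=O)(O)Oc3cccnc3)O2)cc1F`, gives 16.7 h.

Compound 2 differs from compound 1 in one place: quinolin-6-yl in place of pyridin-3-yl on an oxygen. In this assay this made a 1.1-fold higher number from compound 1 to compound 2 (0.06 log units; within the scatter). Compound 3 stands apart from compound 1 by a change in its core: hydrogen in place of benzoyl on an oxygen on a saturated carbon. That step made a 2.5-fold higher number from compound 1 to compound 3 (0.40 log units; beyond the scatter).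

Compound 4, `O=c1[nH]c(=O)n([C@H]2C[C@H](O)[C@@H](COP(=O)(O)Oc3ccc4ncccc4c3)O2)cc1F`, has not yet been measured in this assay. It differs from compound 3 by quinolin-6-yl in place of pyridin-3-yl on an oxygen. For the measured compounds named here, this is the same change as the one from compound 1 to compound 2, at an oxygen whose other neighbour is phosphorus in both cases, but now made on the core of compound 3.

Compound 4 is expected to show a 1.1-fold higher number from compound 3 to compound 4 (0.03 log units; within the scatter), because the same change gave a 1.1-fold higher number from compound 1 to compound 2 (0.06 log units; within the scatter). Two compounds are a thin base for this expectation, and the two cores might not respond alike. Compound 4 is estimated at 18 h in this assay, with a likely span from 10 h to 32 h.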

Compound 4, half-life: 26 h
Compound 4: middle estimate off by 1.4-fold (0.16 log units), on the low side; low and high end bracket the measured number.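

In this assay, quinolin-6-yl in place of pyridin-3-yl on an oxygen gave a 1.6-fold higher number from compound 3 to compound 4 (0.19 log units; within the scatter), against a 1.1-fold higher number from compound 1 to compound 2 (0.06 log units; within the scatter) on the core of compound 1, so on neither core does the step stand out from the scatter. This shows that the change carried across these two cores without a readable shift, but it does not show that the change is without effect on other cores, as each core offers a single pair and a modest difference could lie hidden in the scatter. The other step, hydrogen in place of benzoyl on an oxygen on a saturated carbon, gave a 3.4-fold higher number from compound 2 to compound 4 (0.53 log units; beyond the scatter), in the same direction as a 2.5-fold higher number from compound 1 to compound 3 (0.40 log units; beyond the scatter), and nothing at hand speaks to what lies behind either step.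

The compounds shown leave open how the half-life would read with phenyl, or with an aromatic ring carrying an amine or a carboxylic acid, in place of pyridin-3-yl on that oxygen. They also leave open whether acetyl in place of benzoyl would give a number closer to that of the benzoyl compounds or to that of the hydrogen compounds.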